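A few compounds are considered here, and "the series" means these few. Any claim that something is new, unique, unknown or untested is made for them only; others in the source may bear on it.

Measured so far:
compound 1 `O=C1CCCN(c2ccccc2Cl)N1`, 99000 nM
compound 2 `O=C1CCCN(c2cccc(Cl)c2)N1`, 2500 nM

In an assay on isolated protein for inhibition of Polyunsaturated fatty acid 5-lipoxygenase (Homo sapiens) (a higher number here means a weaker inhibitor, a lower number a stronger inhibitor), compound 2 gives 2500 nM, the lowest of the two numbers, while compound 1 gives 99000 nM, a gap beyond the scatter. Compound 3 `N#Cc1cccc(N2CCCC(=O)N2)c1` has not been measured. It differs from compound 2 by cyano in place of chloro on an aromatic carbon, meta to a group of 7 heavy atoms. For the measured compounds named here, no measured pair shows this change, so only a modest step is expected, if anything toward a higher number, near the edge of the scatter. Compound 3 is expected to give 4000 nM, between 1000 nM and 16000 nM. The expected step is a 1.6-fold higher number from compound 2 to compound 3 (0.20 log units; within the scatter).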

Compound 3, half-maximal inhibitory concentration: 9300 nM
Beside the measured number, compound 3's estimate is 2.3-fold (0.37 log units) below it, and the stated range covers the measured number.
By their numbers in this assay, from the lowest: compound 2; then compound 3; then compound 1.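

The earlier compounds shown here varied only the place of the chloro. Here, cyano in place of chloro on an aromatic carbon, meta to a group of 7 heavy atoms, gives a 3.7-fold higher number from compound 2 to compound 3 (0.57 log units; beyond the scatter) in this assay, so the number at this position depends on which group is present as well as where it sits. The added hydrogen-bond acceptor of the cyano group brings no lower number, and nothing measured here accounts for the step.

The compounds shown leave open whether bromo, methoxy or an amine at this position would match or improve on chloro. They also leave open whether a second chloro on the aromatic ring would lower the number.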